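Amide-linked pyridine analogues against a heat-sensing ion channel

The compounds below may be only part of what the source reports. "The series", "measured", "known", "first", "only" and "open" are said of these compounds alone.

Measured so far:
- compound 1, `O=C(Nc1ccccc1)c1ccc(-c2ncccc2C(F)(F)F)cc1`: "not determined" (no result reported)
- compound 2, `Cc1cccnc1-c1ccc(C(=O)Nc2ccc(C(C)C)cc2)cc1`: 43 nM
- compound 3, `CCCNc1cccnc1-c1ccc(C(=O)Nc2ccc(C(C)(C)C)cc2)cc1`: 37 nM

These three compounds share a core in which an amide links two aromatic rings, one of them carrying a six-membered nitrogen-containing ring. In a functional assay for antagonist activity at transient receptor potential cation channel subfamily V member 1 (Rattus norvegicus) (on this read-out higher numbers stand for weaker inhibition and lower numbers for stronger inhibition), compound 2 gives 43 nM and compound 3 gives 37 nM. In this assay compound 1 gives "not determined" (no result reported). Going by the values given here, with only two numbers, compound 3 stands alongside compound 2: the two values lie within the usual scatter of each other, so neither can be called the stronger inhibitor.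

The next compound, compound 4, `CN(C)Cc1cccnc1-c1ccc(C(=O)Nc2ccc(C(C)(C)C)cc2)cc1`, keeps every atom of compound 3 but joins them differently: (dimethylamino)methyl in place of propylamino on an aromatic carbon. Among the compounds with values here, no step between two measured compounds is available to guide the size of this change. Compound 2 and compound 3, which differ in more than one place, give numbers that barely move, so a step from compound 3 to compound 4 that stays within the scatter is expected. Compound 4 is therefore estimated at 50 nM, with a range from 15 nM to 170 nM, which means an expected step of a 1.4-fold higher number from compound 3 to compound 4 (0.13 log units; within the scatter).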

Compound 4, half-maximal inhibitory concentration: 234 nM
The estimate for compound 4 lay 4.7-fold (0.67 log units) below the measured number; the measured number lies above the stated range.
By their numbers in this assay, from the lowest: compounds 3 and 2 (each within the scatter of the next); then compound 4.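

In this assay the swap of propylamino for (dimethylamino)methyl on this aromatic carbon, two atoms from the ring nitrogen, gives a 6.3-fold higher number from compound 3 to compound 4 (0.80 log units; beyond the scatter) and this step lies beyond the scatter. The two groups have the same atoms joined differently, so this position responds to how those atoms are arranged and not only to which atoms are present. Propylamino has 1 hydrogen-bond donor and (dimethylamino)methyl has 0 hydrogen-bond donors, but no measurement here ties the weaker inhibition to that or to any other difference between the groups.

From the compounds shown here alone, it remains open how a plain amine, methylamino or a longer chain such as butylamino would behave at this position. A single pair also cannot show whether the same swap would give a similar step on a different amide partner.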